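Swapping an indole for a trifluoromethoxyphenyl at the limit

This account rests on a few compounds, and the source may have more. Where it says the series, first, only, none or still open, it means among the compounds named here.

Compound 1 `CC(C)N(Cc1cccc(OCCCCCC(=O)O)c1)C(=O)c1ccc(-c2cccc(OC(F)(F)F)c2)cc1` — > 26000 nM
Compound 2 `CCOC(=O)CCCCCOc1cccc(CN(C(=O)c2ccc(-c3ccc4[nH]ccc4c3)cc2)C(C)C)c1` — > 26000 nM

In an ADME assay on Raji cells (Homo sapiens) for cytotoxicity, read by CellTiter-Glo and resazurin assay, with a stated time of 72 h (a lower number here means that less compound is needed, a higher number that more compound is needed for the effect), compound 1 gives > 26000 nM, which is a limit of the assay rather than a measured number. Compound 2 gives > 26000 nM, and this too is only a limit. Among the compounds with values here, compound 2 thus stands at the ceiling of what the assay can report, and it shares that position with the only other measured compound: the limit of > 26000 nM in this assay, at which 2 of the 2 values shown sit.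

Compound 3 `CCOC(=O)CCCCCOc1cccc(CN(C(=O)c2ccc(-c3cccc(OC(F)(F)F)c3)cc2)C(C)C)c1` differs from compound 2 in one place: 3-(trifluoromethoxy)phenyl in place of 1H-indol-5-yl on an aromatic carbon. Within the data shown here, no measured pair shows what this change does in this assay. Since both measured values sit at the limit, no step beyond the usual scatter is expected in either direction, and the step is expected to be a step that the limit leaves unreadable from compound 2 to compound 3. Compound 3 is estimated at 30000 nM, within 15000 nM to 100000 nM, and most likely the assay will again report only a limit.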

Compound 3, half-maximal effective concentration: > 26000 nM
Compound 3: a limit, no number (the forecaster's own chance of this, stated with the estimate: 85%); the middle value does not contradict the limit.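

No step from compound 1 or compound 2 to compound 3 can be read, as all three compounds stand at the same limit and not at a number: the limit of > 26000 nM in this assay, at which 3 of the 3 values shown sit.

On these data alone, what stays open is the concentration at which any of these three compounds would reach the effect in this assay, and whether either change would shift it.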